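Methyl in Place of Hydrogen: from Compound 2 to Compound 4

A few compounds are considered here, and "the series" means these few. Any claim that something is new, unique, unknown or untested is made for them only; others in the source may bear on it.

Three compounds of the series have numbers in an assay on isolated protein for inhibition of Rho-associated protein kinase 2 (Homo sapiens); a higher number here means a weaker inhibitor, a lower number a stronger inhibitor. Compound 1 `COc1cccc(CN(C)C(=O)c2cc3ccc(-c4cn[nH]c4)cc3[nH]2)c1` gives 3 nM in this assay. Compound 3 `COc1cccc(CNC(=O)c2cc3ccc(-c4cn[nH]c4)nc3n2CCCO)c1` gives 24 nM in this assay. Compound 2 `COc1cccc(CNC(=O)c2c[nH]c3cc(-c4cn[nH]c4)ccc23)c1` gives only a limit of the assay, < 1 nM, so no number stands for it. Compound 2 thus sits at the limit of < 1 nM in this assay, at which 1 of the 3 values shown sits. Among the measured compounds shown here, compound 2 and compound 3 differ in more than one place, so their pair shows no single change, and the same holds for compound 1 against either of them; no step between measured compounds is known.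

The next compound, compound 4 `COc1cccc(CNC(=O)c2cn(C)c3cc(-c4cn[nH]c4)ccc23)c1`, differs from compound 2 in one place: methyl in place of hydrogen on an aromatic nitrogen. Nothing measured in the series tells what this change does, so the expectation rests on the shared core alone. The step from compound 2 to compound 4 in this assay is expected to go toward weaker inhibition and beyond the usual scatter, as an at least 10-fold higher number from compound 2 to compound 4 (1.00 log units; beyond the scatter). Compound 4 is therefore estimated at 10 nM in this assay, within a range from 2 nM to 50 nM.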

Compound 4, half-maximal inhibitory concentration: < 1 nM
Compound 4: no number, only a limit; the forecaster's own chance of this, stated with the estimate: 10%; middle value at least 10-fold (1.00 log units) from the limit.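

In this assay compound 4 gives < 1 nM, which is a limit and not a number; compound 2 also stands at a limit, so no step between compound 2 and compound 4 can be read: the limit of < 1 nM in this assay, at which 2 of the 4 values shown sit.

The compounds shown leave open what methyl in place of hydrogen on an aromatic nitrogen does to inhibition.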